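This account rests on a few compounds, and the source may have more. Where it says the series, first, only, none or still open, it means among the compounds named here.

Measured so far in a functional assay, with a stated time of 10 min; a higher number here means a weaker inhibitor, a lower number a stronger inhibitor 
- compound 1 `O=c1cc(/C=C/c2ccc([N+](=O)[O-])cc2)[nH]cc1O` gives 4790 nM 
- compound 2 `O=c1cc(/C=C/c2ccc(O)cc2)[nH]cc1O` gives 1730 nM 

Of the two, compound 2 has the lower number, at 1730 nM here. Compound 3 `Cn1cc(O)c(=O)cc1/C=C/c1ccc(O)cc1` differs from it by one change: methyl in place of hydrogen on an aromatic nitrogen on the shared core. For the measured compounds named here, the only measured step, a 2.8-fold lower number from compound 1 to compound 2 (0.44 log units; beyond the scatter), swaps nitro for hydroxy on an aromatic carbon and leaves that nitrogen untouched, so it offers only a rough guide to size. Going by the values given here, no measured compound carries this methyl, so the direction is open, and in this assay a step no larger than that modest one is expected. The expected step is a 1.3-fold higher number from compound 2 to compound 3 (0.10 log units; within the scatter) and lies within what this estimate allows. For compound 3 the estimated value is 2200 nM, with an expected range from 700 nM to 7000 nM overall.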

Compound 3, half-maximal inhibitory concentration: 1370 nM
Compound 3: middle estimate off by 1.6-fold (0.21 log units), on the high side; the range from low to high includes it.
By their numbers in this assay, from the lowest: compounds 3 and 2 (each within the scatter of the next); then compound 1.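

In this assay, putting methyl on the aromatic nitrogen of the shared core gives a 1.3-fold lower number from compound 2 to compound 3 (0.10 log units; within the scatter), so this position accepts methyl in place of hydrogen with no step beyond the scatter. The hydrogen on that nitrogen is therefore not required for the activity seen here, which the earlier nitro-to-hydroxy step could not show. Nothing available explains this result. The compounds shown leave open whether this nitrogen would also accept a longer chain, such as propyl or benzyl. They also leave open how a chain ending in an amine or a carboxylic acid would read here.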